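The source may hold more compounds than are shown below. What is called first, only, known or untested is meant among the compounds shown, and "the series" means these compounds.

Measured so far:
- compound 1, `O=C(NC1(c2ccc3c(n2)CCN3C(=O)OC2CC2)CCC1)c1ccc(Cl)cc1`: 63 nM
- compound 2, `O=C(Nc1ccc(Cl)cc1)C1(c2ccc3c(n2)CCN3c2ccccn2)CCC1`: 340 nM

Both numbers come from an assay on blood for inhibition of Indoleamine 2,3-dioxygenase 1 (Homo sapiens); on this read-out lower numbers stand for stronger inhibition and higher numbers for weaker inhibition. Compound 2 stands at the highest of the two numbers, with compound 1 the nearest at a markedly lower number, beyond the usual scatter. Going by the values given here, compound 1 and compound 2 differ in more than one place, so no single step between them is computed; their two values show only that compound 1 gives the lower number in this assay.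

The next compound, compound 3, `O=C(OC1CC1)N1CCc2nc(C3(C(=O)Nc4ccc(Cl)cc4)CCC3)ccc21`, is taken from compound 2 by one change: cyclopropyloxycarbonyl in place of pyridin-2-yl on a nitrogen on an aromatic ring in a ring. Among the compounds with values here, the entering group is the one carried by compound 1 at the same place. Within the data shown here, no step between measured compounds isolates this change, so the size of the step is open. Given that compound 1, which carries this group, gives 63 nM, a move toward lower numbers beyond the scatter is expected for the step of a 3.1-fold lower number from compound 2 to compound 3 (0.49 log units; beyond the scatter). Compound 3 is estimated at 110 nM, within a range of 40 nM to 300 nM.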

Compound 3, half-maximal inhibitory concentration: 90 nM
Compound 3: the middle estimate sits 1.2-fold (0.09 log units) above what was measured; measured number inside the range.
By their numbers in this assay, from the lowest: compounds 1 and 3 (each within the scatter of the next); then compound 2.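

Replacing pyridin-2-yl with cyclopropyloxycarbonyl on the nitrogen of the five-membered non-aromatic ring gives, in this assay, a 3.8-fold lower number from compound 2 to compound 3 (0.58 log units; beyond the scatter) with the rest of the molecule held fixed. This isolates the group on this nitrogen as a source of change in the read-out, and the step comes with no change in heavy-atom count, although the aromatic ring is exchanged for a three-membered ring and a double bond outside aromatic rings. Nothing available accounts for the size of this step.

From the compounds shown here alone, whether the cyclopropyl ring is needed remains open, since methoxycarbonyl or a longer chain such as butoxycarbonyl could be compared at this nitrogen. Also open, going by these compounds, is how acetyl or a plain amine nitrogen bearing only hydrogen would read at this place.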